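The source may hold more compounds than are shown below. What is called first, only, known or untested is meant among the compounds shown, and "the series" means these compounds.

In a functional assay on DU-145 cells (Homo sapiens) for cytotoxicity, read by MTT assay, with a stated time of 24 h (on this read-out lower numbers stand for stronger inhibition and higher numbers for weaker inhibition), compound 1 `O=C1/C(=C/c2ccccc2F)CN(C(=S)SCc2cn(Cc3ccccc3Cl)nn2)C/C1=C\c1ccccc1F` gives 46300 nM and compound 2 `Cc1ccc(/C=C2\CN(C(=S)SCc3cn(Cc4ccc(F)cc4)nn3)C/C(=C\c3ccc(C)cc3)C2=O)cc1` gives 38800 nM, so the two lie within the scatter of each other. Compound 3 `O=C1/C(=C/c2ccccc2F)CN(Cc2cn(Cc3ccc(F)cc3)nn2)C/C1=C\c1ccccc1F` gives 8700 nM, which places it lower than compound 1 by more than the scatter.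

Compound 4 `O=C1/C(=C/c2ccccc2F)CN(C(=S)SCc2cn(Cc3cccc(Cl)c3)nn2)C/C1=C\c1ccccc1F` has not yet been measured. It has the same atoms as compound 1, joined differently: 3-chlorophenyl in place of 2-chlorophenyl on a saturated chain carbon bound to an aromatic nitrogen. In short, 2-chlorobenzyl becomes 3-chlorobenzyl, and the rest of the structure stays the same.

Among the measured compounds shown here, no two measured compounds differ in one place only, so the series gives no direct measure of a change like this. In this assay, no step beyond the scatter is expected, and the value should stay in the range set by compound 1 at 46300 nM and compound 2 at 38800 nM. The estimated 1.1-fold lower number from compound 1 to compound 4 (0.04 log units; within the scatter) is therefore expected to remain within the scatter. For compound 4, the expected value is 42000 nM, with an estimated range of 20000 nM to 85000 nM.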

Compound 4, half-maximal inhibitory concentration: > 80000 nM
Compound 4: no number, only a limit (the forecaster's own chance of this, stated with the estimate: 8%); middle value at least 1.9-fold (0.27 log units) away from the limit.
By their numbers in this assay, from the lowest: compound 3; then compounds 2 and 1 (each within the scatter of the next). At a limit, above all of these: compound 4.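

In this assay compound 4 gives > 80000 nM, which is a limit and not a number. Among the compounds shown here, the change from 2-chlorobenzyl to 3-chlorobenzyl, on the otherwise unchanged structure, is the first change that can be read in one place, and it gives an at least 1.7-fold higher number from compound 1 to compound 4 (0.23 log units; that floor lies within the scatter). The change therefore has a floor rather than a measured size, and since that floor lies within the scatter, the step is not established as beyond it: the limit of > 80000 nM in this assay, at which 1 of the 4 values shown sits.

As far as these compounds go, the true size of the step remains open, as does whether a benzyl without chlorine or a methoxybenzyl in this place would give a value under the limit. From the compounds shown here alone, it is also open whether the same change would read alike on a core carrying 4-methylphenyl groups in place of 2-fluorophenyl.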